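Relocating a chloro group: expected effect on growth inhibition

A few compounds are considered here, and "the series" means these few. Any claim that something is new, unique, unknown or untested is made for them only; others in the source may bear on it.

compound 1 `COc1cc2c(/C=C3/C(=O)Nc4ccc(O)cc43)c(Cl)n(Cc3cc(OC)c(OC)c(OC)c3)c2cc1C` — 2400 nM
compound 2 `COc1cc2c(/C=C3/C(=O)Nc4ccc(Cl)cc43)c(Cl)n(Cc3cc(OC)c(OC)c(OC)c3)c2cc1C` — 2290 nM
compound 3 `O=C1/C(=C/c2c(Cl)[nH]c3ccccc23)c2ccccc2N1Cc1ccccc1` — 6610 nM

All three compounds were tested in a functional assay on NSCLC cells (Homo sapiens) for cytotoxicity, with a stated time of 48 h; a higher number here means a weaker inhibitor of growth, a lower number a stronger inhibitor of growth. Compound 1 stands second highest of the three numbers: compound 2 sits within the scatter of it, while compound 3 gives the highest number, beyond the scatter from compound 1.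

Compound 4 `COc1cc2c(/C=C3/C(=O)Nc4cccc(Cl)c43)c(Cl)n(Cc3cc(OC)c(OC)c(OC)c3)c2cc1C` differs from compound 1 by a group of 12 heavy atoms (9 carbon, 1 nitrogen, 1 oxygen, 1 chlorine; one five-membered non-aromatic ring with 1 hetero atom, one six-membered aromatic ring of carbon only) in place of a group of 12 heavy atoms (9 carbon, 1 nitrogen, 2 oxygen; one five-membered non-aromatic ring with 1 hetero atom, one six-membered aromatic ring of carbon only), on an aromatic carbon. Within the data shown here, only one measured step touches this part of the molecule: a 1.0-fold lower number from compound 1 to compound 2 (0.02 log units; within the scatter), an exchange that left the number essentially unchanged. Because a 1.0-fold lower number from compound 1 to compound 2 (0.02 log units; within the scatter) stayed within the scatter, the step of no change at the digits printed from compound 1 to compound 4 (within the scatter) is expected to stay within the scatter as well, with no clear direction. Compound 4 is therefore estimated at 2400 nM, with a likely range from 1000 nM to 5500 nM.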

Compound 4, concentration for 50% growth inhibition: 3240 nM
Beside the measured number, compound 4's estimate is 1.4-fold (0.13 log units) below it, and the stated range covers the measured number.
By their numbers in this assay, from the lowest: compounds 2, 1 and 4 (each within the scatter of the next); then compound 3.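

In this assay, moving the chloro group to another carbon of the six-membered aromatic ring gives a 1.4-fold higher number from compound 2 to compound 4 (0.15 log units; within the scatter), while the full exchange from the hydroxy compound gives a 1.4-fold higher number from compound 1 to compound 4 (0.13 log units; within the scatter). The earlier result therefore extends to a second placement: with the chloro group at either carbon, the number stays within the scatter of the hydroxy compound and of the other chloro compound. No measurement shown here offers an explanation for this. Still open, as far as these compounds go, is whether an amine or a carboxylic acid on this ring would shift the number beyond the scatter.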